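Side chain change from compound 2 to compound 4

The compounds below may be only part of what the source reports. "The series", "measured", "known", "first", "only" and "open" are said of these compounds alone.

Measured so far in a functional assay on HT-29 cells (Homo sapiens) for antiproliferative activity, read by XTT assay, with a stated time of 72 h (a lower number here means a stronger inhibitor, a higher number a weaker inhibitor), for this series:
compound 1 `C=C(C)CCC[C@]1(C)C2=CCC[C@](C)(C[C@H](OC(C)=O)C3=CC(=O)OC3O)[C@H]2CC[C@H]1C` gives 4200 nM
compound 2 `C=C(C)CCC[C@]1(C)C2=CCC[C@](C)(C[C@@H](OC(C)=O)C3=CC(=O)OC3O)[C@H]2CC[C@H]1C` gives 2900 nM
compound 3 `C=C(C)CCC[C@]1(C)C2=CCC[C@](C)(C[C@@H](O)C3=CC(=O)OC3O)[C@H]2CC[C@H]1C` gives 2300 nM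

On these numbers compound 2 cannot be separated from the other two, with a 1.4-fold lower number from compound 1 to compound 2 (0.16 log units; within the scatter) and a 1.3-fold lower number from compound 2 to compound 3 (0.10 log units; within the scatter) both within the scatter. The change to compound 4 `C=C(C)CC[C@]1(C)C2=CCC[C@](C)(C[C@@H](OC(C)=O)C3=CC(=O)OC3O)[C@H]2CC[C@H]1C` is 1-methylethenyl in place of 2-methylprop-2-en-1-yl on a saturated chain carbon, two bonds along the chain from a saturated ring carbon on a saturated chain carbon, two bonds along the chain from a saturated ring carbon. Neither measured step touches this chain. One alters a stereocentre and the other puts hydrogen in place of acetyl, so they are only a loose guide to step size. With compound 2 at 2900 nM as the anchor, no step beyond the scatter is expected in this assay and no direction is favoured. The expected step is a 1.0-fold higher number from compound 2 to compound 4 (0.01 log units; within the scatter) and it stays within the scatter. The estimate for compound 4 is 3000 nM with an expected range of 1300 nM to 6500 nM around it.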

Compound 4, half-maximal inhibitory concentration: 4800 nM
Compound 4: middle estimate off by 1.6-fold (0.20 log units), on the low side; low and high end bracket the measured number.
By their numbers in this assay, from the lowest: compounds 3, 2, 1 and 4 (each within the scatter of the next, the first and the last beyond it).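

For the compounds shown here, this is the first measured change on the side chain: 1-methylethenyl in place of 2-methylprop-2-en-1-yl, on a saturated chain carbon, two bonds along the chain from a saturated ring carbon, gives a 1.7-fold higher number from compound 2 to compound 4 (0.22 log units; within the scatter) in this assay. The chain thus accepts this shortening without a step beyond the scatter, and this single pair sets no direction. Nothing at hand bears on the basis of this step.

As far as these compounds go, whether an amine, a carboxylic acid or a longer chain at this place would move the number beyond the scatter remains open. So does whether the same shortening behaves alike on the free alcohol of compound 3.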